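Swapping a Chain for a Ring on a Sulfonamide

A few compounds are considered here, and "the series" means these few. Any claim that something is new, unique, unknown or untested is made for them only; others in the source may bear on it.

Compound 1, `CC(=O)N1CC2(C1)CC(NS(=O)(=O)c1ccc(OCc3cc(C)nc4ccccc34)cc1)(C(=O)NO)C2`: 17000000 nM
Compound 2, `Cc1cc(COc2ccc(S(=O)(=O)NCCC(=O)NO)cc2)c2ccccc2n1`: 4100000 nM

Both compounds were tested in a physicochemical assay for solubility, with a stated time of 24 h, tested at 30 mg/mL; on this read-out lower numbers stand for lower solubility and higher numbers for higher solubility. Compound 2 gives the lower of the two numbers, and the gap to compound 1 lies beyond the usual scatter. Compound 3, `Cc1cc(COc2ccc(S(=O)(=O)NC3(C(=O)NO)CCCCC3)cc2)c2ccccc2n1`, keeps the core of compound 2 and changes one place: a group of 10 heavy atoms (7 carbon, 1 nitrogen, 2 oxygen; one six-membered non-aromatic ring of carbon only) in place of a group of 6 heavy atoms (3 carbon, 1 nitrogen, 2 oxygen; no ring), on a sulfonamide nitrogen. Among the measured compounds shown here, no measured pair shows a change of this kind, so the expectation is a modest downward step, a 2.7-fold lower number from compound 2 to compound 3 (0.44 log units; beyond the scatter), probably not far beyond the scatter. Compound 3 is therefore expected to give about 1500000 nM, within a range from 400000 nM to 6000000 nM.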

Compound 3, solubility: 11000000 nM
Estimate against measurement, compound 3: 7.3-fold (0.87 log units) below; measured number outside the range, above it.
By their numbers in this assay, from the lowest: compound 2; then compounds 3 and 1 (each within the scatter of the next).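

In this assay the sulfonamide nitrogen shows its first measured change: there is a 2.7-fold higher number from compound 2 to compound 3 (0.43 log units; beyond the scatter) when the group with a six-membered carbon ring replaces the 2-(hydroxycarbamoyl)ethyl group. At this position, then, the larger ring-bearing group, with the same counts of hydrogen-bond donors and acceptors, goes with a higher number. Nothing measured here explains the step. As far as these compounds go, whether the ring or the added carbon atoms matter remains open; a longer open chain or a five-membered carbon ring at this nitrogen could help separate the two.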